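The source may hold more compounds than are shown below. What is called first, only, known or untested is meant among the compounds shown, and "the series" means these compounds.

Three compounds share one core. Compound 1 is `CS(=O)(=O)c1ccc(Cl)cc1NCC1=NCCN1`. In a functional assay for agonist activity at Alpha-1D adrenergic receptor (Homo sapiens) (a lower number here means that less compound is needed, a higher number that more compound is needed for the effect), compound 1 reaches only a limit of the assay, < 100000 nM. Compound 2 is `CS(=O)(=O)c1ccc(F)cc1NCC1=NCCN1`. In this assay compound 2 likewise gives only a limit, < 100000 nM. Compound 3 is `COc1ccc(S(C)(=O)=O)c(NCC2=NCCN2)c1`. In this assay compound 3 again gives only a limit, < 100000 nM. The steps among them therefore cannot be read: a step that the two limits leave unreadable from compound 1 to compound 2, a step that the two limits leave unreadable from compound 1 to compound 3 and a step that the two limits leave unreadable from compound 2 to compound 3. Where compound 3 stands is thus known only as a limit, the same limit at which the two other values sit (the limit of < 100000 nM in this assay, at which 3 of the 3 values shown sit). Compound 4 is `CS(=O)(=O)c1ccc(C(F)(F)F)cc1NCC1=NCCN1`; it differs from compound 3 by trifluoromethyl in place of methoxy on an aromatic carbon. The two measured steps into compound 3 touch the same aromatic carbon and so bear on this change, but their size is not readable, so no direction or size of step in this assay can be drawn from them. Compound 4 is estimated at 3000 nM, within a range from 100 nM to 100000 nM, which would mean an expected step that the limit leaves unreadable from compound 3 to compound 4.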

Compound 4, half-maximal effective concentration: < 100000 nM
Compound 4 ended at the assay's limit; the forecaster's own chance of this, stated with the estimate: 30%; the middle value lies beyond the limit too.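

In this assay compound 4 also gives only a limit, < 100000 nM. No step among compound 1, compound 2, compound 3 and compound 4 can be read: the limit of < 100000 nM in this assay, at which 4 of the 4 values shown sit.

The compounds shown leave open whether chloro, fluoro, methoxy and trifluoromethyl differ at all in this assay.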